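The source may hold more compounds than are shown below. What is called first, only, known or untested is meant among the compounds shown, and "the series" means these compounds.

Three compounds have been measured in an ADME assay on the whole organism with Oryza sativa as the target, tested at 0.1 uM; a lower number here means a stronger effect, a higher number a weaker effect of the compound at the concentration tested:

compound 1 `C[C@H](NC(=O)Nc1ccccc1C(C)(C)C)c1ccccc1`: 101%
compound 2 `C[C@H](NC(=O)Nc1ccccc1C(F)(F)F)c1ccccc1`: 97%
compound 3 `COc1ccccc1NC(=O)N[C@@H](C)c1ccccc1`: 98%

Compound 3 gives the second highest of the three numbers. Its nearest neighbour is compound 2, with a number 1 percentage points higher from compound 2 to compound 3 (within the scatter), and its furthest is compound 1, with a number 3 percentage points lower from compound 1 to compound 3 (within the scatter); both steps lie within the scatter, so the three compounds cannot be told apart on these numbers.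

Compound 4 `C[C@H](NC(=O)Nc1ccccc1Br)c1ccccc1` is not yet measured. It differs from compound 3 in one place: bromo in place of methoxy on an aromatic carbon.

The three measured steps all exchange the group at this same place, and each stayed within the scatter: a number 4 percentage points lower from compound 1 to compound 2 (within the scatter), a number 3 percentage points lower from compound 1 to compound 3 (within the scatter) and a number 1 percentage points higher from compound 2 to compound 3 (within the scatter). Going by the values given here, none of them involves bromo, so there is no direct precedent for this group. Taken together they suggest that exchanging the group here leaves this assay unchanged, and no step beyond the scatter is therefore expected for compound 4, that is no change at the digits printed from compound 3 to compound 4 (within the scatter). The estimate for compound 4 is 98%, with a range from 88% to 108%.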

Compound 4, a percentage reported as activity, at one concentration (the size of the read-out at that concentration, not a potency): 101%
Beside the measured number, compound 4's estimate is 3 percentage points below it; the range from low to high includes it.
By their numbers in this assay, from the lowest: compounds 2, 3, 1 and 4 (each within the scatter of the next).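

In this assay, bromo is a fourth group on this aromatic carbon, and all of its steps stay within the scatter (a number 3 percentage points higher from compound 3 to compound 4 (within the scatter); a number 4 percentage points higher from compound 2 to compound 4 (within the scatter); no change at the digits printed from compound 1 to compound 4 (within the scatter)). The position therefore now holds a single bromine atom as well as the larger tert-butyl, trifluoromethyl and methoxy groups, and no exchange among these four separates the compounds on this read-out. No supporting measurement bears on this result, so nothing can be said about what lies behind it.

The compounds shown leave open whether an amine, a carboxylic acid or a longer chain on this aromatic carbon would give a step beyond the scatter. They also leave open whether any change elsewhere on the shared core would move the number, since all four compounds lie within the scatter of one another.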